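A few compounds are considered here, and "the series" means these few. Any claim that something is new, unique, unknown or untested is made for them only; others in the source may bear on it.

Compound 1, `CS(=O)(=O)c1ccc(-c2oc3ccccc3c(=S)c2-c2ccc(F)cc2)cc1`, was measured in an assay on isolated protein for inhibition of prostaglandin G/H synthase 1 (Mus musculus), tested at 10 ug/mL; a lower number here means less inhibition, a higher number more inhibition at the concentration tested (going by the name of the read-out). In this assay compound 1 gives < 5%, which is a limit of the assay rather than a number, and it marks (the limit of < 5% in this assay, at which 1 of the 2 values shown sits). Among the compounds with values here, a second measured compound, compound 2, `NS(=O)(=O)c1ccc(-c2oc3ccccc3c(=O)c2-c2ccccc2)cc1`, gives 61% in this assay; no step between compound 2 and compound 1 has been worked out, so the two values simply stand side by side.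

Compound 3, `CS(=O)(=O)c1ccc(-c2oc3ccccc3c(=S)c2-c2ccc(Cl)c(Cl)c2)cc1`, is not yet measured in this assay. It differs from compound 1 in one place: 3,4-dichlorophenyl in place of 4-fluorophenyl on an aromatic carbon. Within the data shown here, with compound 1 sitting at a limit, there is no measured step from which the size of this change can be read, and the shared core of compound 1 carries over unchanged. The expected step is therefore small, a number at least 3 percentage points higher from compound 1 to compound 3 (that floor lies within the scatter), and is not expected to exceed the usual scatter of repeated measurements. On that basis compound 3 is estimated to give about 8% in this assay, within a range from 0% to 25%, with a real chance that the assay again reports only a limit.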

Compound 3, a percentage reported as inhibition, at one concentration (the size of the read-out at that concentration, not a potency): < 5%
Compound 3 ended at the assay's limit (the forecaster's own chance of this, stated with the estimate: 55%); middle value at least 3 percentage points from the limit.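

Compound 1 and compound 3 each give a limit of the assay rather than a number in this assay, so no step between them can be read: the limit of < 5% in this assay, at which 2 of the 3 values shown sit.

The compounds shown leave open whether 3,4-dichlorophenyl in place of 4-fluorophenyl changes inhibition at all, and if it does, by how much and in which direction.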